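The source may hold more compounds than are shown below. What is called first, only, known or untested is meant among the compounds shown, and "the series" means these compounds.

Compound 1, `CCOC(=O)N(C)C(C)C#CCN1CCCC1`: in a functional assay on the whole organism for agonist activity, with Mus musculus as the target (a lower number here means that less compound is needed, a higher number that more compound is needed for the effect), compound 1 reaches only the assay limit > 100 mg/kg.
Compound 2, `CCOC(=O)N(C)C(C)C#CCn1ccnc1`: in this assay compound 2 likewise reaches only the limit > 100 mg/kg.
Compound 3, `CC(C#CCN1CCCC1)N1CCN(C)C1=O`: in this assay compound 3 reaches only the limit > 30 mg/kg.

None of the three measured compounds gives a number in this assay; each stops at a limit, as the limit of > 100 mg/kg in this assay, at which 2 of the 3 values shown sit, and the limit of > 30 mg/kg in this assay, at which 1 of the 3 values shown sits, record. Compound 1 and compound 2 share a core and differ by 1H-imidazol-1-yl in place of pyrrolidin-1-yl on a saturated chain carbon bound to a triple-bonded carbon. Because both values are limits, the step that the two limits leave unreadable from compound 1 to compound 2 cannot be sized. Compound 3 carries a different core; the difference between the two cores is not broken down here.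

Compound 4, `CC(C#CCn1ccnc1)N1CCN(C)C1=O`, has not yet been measured. It stands to compound 3 as compound 2 stands to compound 1, differing by 1H-imidazol-1-yl in place of pyrrolidin-1-yl on a saturated chain carbon bound to a triple-bonded carbon, at the same place in both pairs, so it is the same change. The earlier instance of this change gave no readable step, and compound 3 itself sits at a limit, so the expected step that the limit leaves unreadable from compound 3 to compound 4 is estimated close to nothing. Compound 4 is therefore expected to give about 100 mg/kg, most probably again only a limit, within an estimated range of 30 mg/kg to 300 mg/kg.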

Compound 4, dose for half-maximal effect: > 100 mg/kg
Compound 4: a limit, no number; the forecaster's own chance of this, stated with the estimate: 85%; the middle value lies on the limit itself.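

In this assay, among the compounds shown here, compound 4 gives only the limit > 100 mg/kg, and compound 3 also stands at a limit, so no step from compound 3 to compound 4 can be read. The compounds shown leave open what dose any of them needs for a half-maximal effect, and whether exchanging pyrrolidin-1-yl for 1H-imidazol-1-yl changes that dose.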